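This account rests on a few compounds, and the source may have more. Where it says the series, first, only, none or still open, it means among the compounds named here.

Series notes, cytotoxicity in a functional assay on Hs-578T cells (Homo sapiens) for cytotoxicity, read by sulforhodamine B assay, with a stated time of 48 h; on this read-out lower numbers stand for higher toxicity in this test and higher numbers for lower toxicity in this test.
Compound 1 `ClCc1ccc(Cn2cnc3c(Cl)ncnc32)cc1`: reported as a limit, > 100000 nM.
Compound 2 `ClCc1ccccc1Cn1cnc2ncnc(Cl)c21`: 66100 nM.
Compound 3 `ClCc1ccc(Cn2cnc3c(Cl)nc(Cl)nc32)cc1`: reported as a limit, > 100000 nM.

Among the compounds with values here, compound 2 is the only compound in this assay with a number; the other two values are limits. The difference between the cores of compound 1 and compound 2 is not broken down here. Compound 3 arises from compound 1 by chloro in place of hydrogen on an aromatic carbon; the step that the two limits leave unreadable from compound 1 to compound 3 cannot be read, since both values sit at the limit of > 100000 nM in this assay, at which 2 of the 3 values shown sit. Compound 4 `ClCc1ccccc1Cn1cnc2nc(Cl)nc(Cl)c21`, not yet measured, arises from compound 2 by chloro in place of hydrogen on an aromatic carbon, the same change. No readable step exists for this change in this assay. The step from compound 2 to compound 4 is therefore expected to be small, about a 1.4-fold higher number from compound 2 to compound 4 (0.13 log units; within the scatter). This expectation rests on compound 2 alone, which gives 66100 nM. Compound 4 is estimated at 90000 nM, between 45000 nM and 180000 nM, with a fair chance that only a limit is reported.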

Compound 4, concentration lethal to 50% of the cells: > 100000 nM
Compound 4 ended at the assay's limit (the forecaster's own chance of this, stated with the estimate: 45%); middle value at least 1.1-fold (0.04 log units) away from the limit.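

In this assay, going by these compounds, chloro in place of hydrogen on an aromatic carbon gives an at least 1.5-fold higher number from compound 2 to compound 4 (0.17 log units; that floor lies within the scatter), so on the core of compound 2 the step has only a floor and its true size stays open. Within the data shown here, the same change on the core of compound 1 cannot be read, so the two cores offer no pair of steps to compare: the limit of > 100000 nM in this assay, at which 3 of the 4 values shown sit. This shows only that compound 3 and compound 4, which both carry the added chloro, end at the limit; it does not show that the change has the same size on both cores.

Still open, on these data alone, is how an amine or a carboxylic acid in place of the added chloro would read in this assay.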